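Moving a chlorine on a diacylhydrazine ecdysone agonist

The source may report more compounds than this note shows. Statements on the series, on what has been measured and on what is new or still open speak of the compounds shown alone.

Of the compounds shown here, three sharing a diacylhydrazine core have been measured in an assay on cells for agonist activity at ecdysone receptor (Bombyx mori), read by a luciferase reporter, with a stated time of 24 h; on this read-out higher numbers stand for an effect only at larger amounts of compound and lower numbers for an effect already at smaller amounts. Compound 1 `CC(C)(C)N(NC(=O)c1ccccc1)C(=O)c1ccccc1I` gives 105 nM. For the measured compounds named here, compound 2 `Cc1ccccc1C(=O)N(NC(=O)c1ccccc1)C(C)(C)C` gives 224 nM, and the only single change among the measured compounds, a 2.1-fold higher number from compound 1 to compound 2 (0.33 log units; beyond the scatter), is modest. Compound 3 `CC(C)(C)N(NC(=O)c1ccccc1Cl)C(=O)c1ccccc1Cl` gives 331 nM, the highest of the three numbers: against compound 2 it sits within the scatter, while against compound 1 it is beyond it.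

Compound 4 `CC(C)(C)N(NC(=O)c1cccc(Cl)c1)C(=O)c1ccccc1Cl` differs from compound 3 in one place: 3-chlorophenyl in place of 2-chlorophenyl on a carbonyl carbon. Going by the values given here, no measured step concerns moving a chlorine from one ring position to another, so the single step between compound 1 and compound 2 offers no direct guide, and the expectation rests on the change itself. Since the two rings keep the same atoms and only the chlorine position changes, a moderate move is expected rather than a large one, and the direction is taken as a somewhat lower number, with wide uncertainty. The step of a 2.1-fold lower number from compound 3 to compound 4 (0.32 log units; beyond the scatter) is the estimated outcome. Compound 4 is therefore expected to give 160 nM in this assay, in a range from 50 nM to 500 nM.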

Compound 4, half-maximal effective concentration: 155 nM
Estimate against measurement, compound 4: 1.0-fold (0.01 log units) above; the range from low to high includes it.
By their numbers in this assay, from the lowest: compounds 1, 4, 2 and 3 (each within the scatter of the next, the first and the last beyond it).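

In this assay, putting 3-chlorophenyl in place of 2-chlorophenyl on a carbonyl carbon gives a 2.1-fold lower number from compound 3 to compound 4 (0.33 log units; beyond the scatter). This is a modest step, but it goes beyond the scatter, so at this place the read-out responds to where the chlorine sits on the ring, even though the atoms of the compound stay the same. The earlier step replaced iodo with methyl and so exchanged one group for a different one, whereas this step keeps the group and changes only how it is joined, although no measurement here explains why the number falls.

The compounds shown leave open how a different group, such as a methoxy group or an amine, would behave in place of this chlorine, and whether moving that group would shift the number in the same direction. They also leave open whether this step depends on the chlorine on the other ring, since both compound 3 and compound 4 carry that second chlorine, and a matching compound with a hydrogen there would be needed to tell.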